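Octyl in place of 4-fluorophenyl: compound 2 to compound 3

The source may hold more compounds than are shown below. What is called first, only, known or untested is meant among the compounds shown, and "the series" means these compounds.

Among the measured compounds shown here, compound 2, `CN(C)C(=O)C[C@H](CSc1ccccc1)Nc1c(C(=O)N/N=C/c2ccc(F)cc2)cnc2ccc(F)cc12`, is one of two compounds measured in an ADME assay on Vero cells (Chlorocebus sabaeus) for cytotoxicity, read by MTT assay, with a stated time of 72 h; a lower number here means a stronger inhibitor, a higher number a weaker inhibitor. In this assay compound 2 gives > 62.5 ug/mL, which is a limit of the assay rather than a number. Compound 1, `CCCCCCCC/C=N/NC(=O)c1cnc2c(C(F)(F)F)cccc2c1N[C@@H](CSc1ccccc1)CC(=O)N(C)C`, likewise returns only a limit, > 62.5 ug/mL. Both values share (the limit of > 62.5 ug/mL in this assay, at which 2 of the 2 values shown sit). Compound 3, `CCCCCCCC/C=N/NC(=O)c1cnc2ccc(F)cc2c1N[C@@H](CSc1ccccc1)CC(=O)N(C)C`, differs from compound 2 by octyl in place of 4-fluorophenyl on a carbon with a double bond to nitrogen. Compound 1 already carries that octyl group and sits at the same limit (the limit of > 62.5 ug/mL in this assay, at which 2 of the 2 values shown sit). The step from compound 2 to compound 3 is therefore expected to be none beyond the scatter, a step that the limit leaves unreadable from compound 2 to compound 3. Compound 3 is estimated at 80 ug/mL, between 45 ug/mL and 200 ug/mL, most probably reported again as a limit.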

Compound 3, half-maximal inhibitory concentration: > 62.5 ug/mL
Compound 3 gave a limit, no number; the forecaster's own chance of this, stated with the estimate: 85%; the middle value lies beyond the limit too.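

In this assay compound 3 gives > 62.5 ug/mL, a limit and not a number. No step can be read between compound 2 and compound 3, since both values are limits. The compounds shown leave open what half-maximal inhibitory concentration any of them would actually reach.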